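A Chloro Group in Place of Hydrogen on the Anilino Ring

The compounds below may be only part of what the source reports. "The series", "measured", "known", "first", "only" and "open" are said of these compounds alone.

Compound 1 `CCCSc1nc(Nc2ccccc2)c2nc(Nc3ccccc3)sc2n1` gives 24400 nM in a functional assay on MGC-803 cells (Homo sapiens) for antiproliferative activity, read by MTT assay, with a stated time of 72 h; on this read-out higher numbers stand for weaker inhibition and lower numbers for stronger inhibition.
Compound 2 `CCCSc1nc(Nc2ccc(OC)cc2)c2nc(Nc3ccccc3)sc2n1` reaches only the assay limit of > 64000 nM in this assay.
Compound 3 `CCCSc1nc(NC2CC2)c2nc(Nc3ccccc3)sc2n1` likewise stands at the limit, > 64000 nM in this assay.

For the measured compounds named here, compound 1 holds the only actual number among the three; the other two values are limits, not numbers (the limit of > 64000 nM in this assay, at which 2 of the 3 values shown sit). Compound 4 `CCCSc1nc(Nc2ccc(Cl)cc2)c2nc(Nc3ccccc3)sc2n1` differs from compound 1 by chloro in place of hydrogen on an aromatic carbon. Going by the values given here, the step that bears most directly on this is the one from compound 1 to compound 2, where a methoxy group entered the same ring and gave an at least 2.6-fold higher number from compound 1 to compound 2 (0.41 log units; beyond the scatter); the step of an at least 2.6-fold higher number from compound 1 to compound 3 (0.41 log units; beyond the scatter) alters a different part of the molecule. From this, compound 4 is expected to inhibit more weakly than compound 1, a step of a 1.8-fold higher number from compound 1 to compound 4 (0.27 log units; within the scatter), which may not clear the scatter. Compound 4 is therefore estimated at 45000 nM, with a range from 12000 nM to 110000 nM.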

Compound 4, half-maximal inhibitory concentration: 12500 nM
Compound 4: the middle estimate sits 3.6-fold (0.56 log units) above what was measured, within the range that was stated.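

In this assay, chloro in place of hydrogen on this anilino ring gives a 2.0-fold lower number from compound 1 to compound 4 (0.29 log units; within the scatter), so chloro keeps the activity of compound 1 at the place where methoxy lost it. Chloro in place of methoxy gives an at least 5.1-fold lower number from compound 2 to compound 4 (0.70 log units; beyond the scatter), which shows that the group at this place matters, and 4-chlorophenyl in place of cyclopropyl gives an at least 5.1-fold lower number from compound 3 to compound 4 (0.70 log units; beyond the scatter). Both of these steps start from a limit, not a number: the limit of > 64000 nM in this assay, at which 2 of the 4 values shown sit.

Still open, going by these compounds, is how fluoro, bromo, methyl or an amine would behave at this place on the ring.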